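Replacing a methoxyphenyl on the shared core of compound 2

The source may hold more compounds than are shown below. What is called first, only, known or untested is meant among the compounds shown, and "the series" means these compounds.

Compound 1: `Cc1cc(OCc2c(-c3cc[nH]c(=O)c3Cl)noc2C(C)C)ccc1-c1ccc2c(C(=O)O)cn(C)c2c1`, 5000 nM
Compound 2: `COc1ccccc1-c1noc(C(C)C)c1COc1ccc(/C=C/c2cccc(C(=O)O)c2)c(Cl)c1`, 10000 nM

In a functional assay for agonist activity at Bile acid receptor (Homo sapiens), read by a luciferase reporter (on this read-out higher numbers stand for an effect only at larger amounts of compound and lower numbers for an effect already at smaller amounts), compound 2 gives 10000 nM, and compound 1 gives 5000 nM; these two numbers lie within the scatter of each other, so neither stands apart. Compound 3, `CC(C)c1onc(-c2ccc(S(C)(=O)=O)cc2Cl)c1COc1ccc(/C=C/c2cccc(C(=O)O)c2)c(Cl)c1`, carries 2-chloro-4-(methylsulfonyl)phenyl in place of 2-methoxyphenyl on an aromatic carbon. Among the compounds with values here, no measured pair differing in one place exists here, so nothing shows what such a change does. Compound 3 is nevertheless expected to give a lower number, a step of a 5.0-fold lower number from compound 2 to compound 3 (0.70 log units; beyond the scatter), because compound 2 sits at 10000 nM. The estimate for compound 3 in this assay is 2000 nM, ranging from 300 nM to 10000 nM.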

Compound 3, half-maximal effective concentration: > 10000 nM
Compound 3: only a limit was reported (the forecaster's own chance of this, stated with the estimate: 15%); at least 5.0-fold (0.69 log units) between middle value and limit.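

At this position on the shared core, next to the ring nitrogen, 2-chloro-4-(methylsulfonyl)phenyl in place of 2-methoxyphenyl gives, in this assay, a number no lower from compound 2 to compound 3 (the limit leaves the size open). This change therefore brings no shift towards an effect at smaller amounts of compound. The reading for compound 3 is a limit, not a number: the limit of > 10000 nM in this assay, at which 1 of the 3 values shown sits.

As far as these compounds go, how far the number rises with this change stays open, and so does the separate share of the chlorine and the methylsulfonyl. From the compounds shown here alone, whether an amine in place of the methylsulfonyl would give a lower number also stays open.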